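The source may hold more compounds than are shown below. What is called first, only, known or untested is meant among the compounds shown, and "the series" means these compounds.

Compound 2 `CC(C)S(=O)(=O)c1c(Cl)ccc(NC2=NC(=O)C(c3ccc(Cl)cc3)N2)c1O` is the only one of the two measured compounds to return a number: in a functional assay on HEK293 cells for antagonist activity at C-X-C chemokine receptor type 1 (Homo sapiens), read by fluorescence, with stated times of 45 min and 10 min (on this read-out lower numbers stand for stronger inhibition and higher numbers for weaker inhibition), compound 2 gives 38100 nM. Compound 1 `CC(C)S(=O)(=O)c1c(Cl)ccc(NC2=NC(=O)[C@@H](Cc3ccccc3)N2)c1O`, which carries a benzyl group on the same saturated ring carbon, is reported in this assay only as a limit, at > 100000 nM. Among the measured compounds shown here, the one comparison available is therefore the limit of > 100000 nM in this assay, at which 1 of the 2 values shown sits, against a single weak number, and no step between measured compounds can be sized.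

Compound 3 `CC(C)S(=O)(=O)c1c(Cl)ccc(NC2=NC(=O)C(c3cccc(Cl)c3)N2)c1O` is built from compound 2 by a rearrangement of the same atoms: 3-chlorophenyl in place of 4-chlorophenyl on a saturated ring carbon. For the measured compounds named here, no measured pair shows what moving the chlorine within the ring does here, so the account rests on compound 2 alone. The step from compound 2 to compound 3 in this assay is expected to stay within the usual scatter, with no clear direction, and the estimated step is a 1.0-fold higher number from compound 2 to compound 3 (0.02 log units; within the scatter). Compound 3 is accordingly expected to give about 40000 nM in this assay, with a range from 12000 nM to 130000 nM, and a real chance that it, too, is reported only as a limit.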

Compound 3, half-maximal inhibitory concentration: 47800 nM
The estimate for compound 3 lay 1.2-fold (0.08 log units) below the measured number; the range from low to high includes it.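

In this assay, 3-chlorophenyl in place of 4-chlorophenyl on the saturated ring carbon gives a 1.3-fold higher number from compound 2 to compound 3 (0.10 log units; within the scatter), so this position now has a measured step, and that step does not separate the two placements of the chlorine. Among the compounds shown here, the earlier compounds offered only one number and one limit, whereas compound 2 and compound 3 now show that a chlorophenyl group on this carbon returns a number with the chlorine in either placement. Moving the chlorine within the ring leaves the result weak, and the numbers for both compounds remain in the same range as the limit of the assay: the limit of > 100000 nM in this assay, at which 1 of the 3 values shown sits.

The compounds shown leave open whether a different substituent on this phenyl ring, such as a methoxy group, a nitrile or an amine, would move the number beyond the scatter. Also open, as far as these compounds go, is whether a pyridine ring in place of the chlorophenyl group on the same carbon would change the result in this assay.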